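A few compounds are considered here, and "the series" means these few. Any claim that something is new, unique, unknown or untested is made for them only; others in the source may bear on it.

Compound 2 `COc1ncc(-c2ccc3nc(NC(=O)NCCN4CCCCC4)sc3c2)cc1NS(=O)(=O)c1ccc(F)cc1` gives 750 nM in a functional assay on U-87MG ATCC cells for antiproliferative activity against U-87 MG (Homo sapiens), read by MTT assay, with a stated time of 72 h; on this read-out lower numbers stand for stronger inhibition and higher numbers for weaker inhibition. Among the measured compounds shown here, of the two numbers measured so far it is the highest, and its nearest neighbour is compound 1 `CCN(CC)CCNC(=O)Nc1nc2ccc(-c3cnc(OC)c(NS(=O)(=O)c4ccc(F)cc4)c3)cc2s1`, which in this assay gives 390 nM. Compound 3 `COc1ncc(-c2ccc3nc(NC(=O)NCCN4CCN(C)CC4)sc3c2)cc1NS(=O)(=O)c1ccc(F)cc1` differs from compound 2 by 4-methylpiperazin-1-yl in place of piperidin-1-yl on a saturated chain carbon, two bonds along the chain from an amide-type nitrogen. For the measured compounds named here, the only measured step that bears on this change is a 1.9-fold higher number from compound 1 to compound 2 (0.28 log units; within the scatter), which stayed within the scatter. No step beyond the scatter is expected because a 1.9-fold higher number from compound 1 to compound 2 (0.28 log units; within the scatter) was itself small. Compound 3 is therefore estimated at 700 nM, with a range from 300 nM to 1600 nM, an expected step of a 1.1-fold lower number from compound 2 to compound 3 (0.03 log units; within the scatter).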

Compound 3, half-maximal inhibitory concentration: 440 nM
Compound 3: middle estimate off by 1.6-fold (0.20 log units), on the high side; low and high end bracket the measured number.
By their numbers in this assay, from the lowest: compounds 1, 3 and 2 (each within the scatter of the next).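

In this assay, 4-methylpiperazin-1-yl in place of piperidin-1-yl gives a 1.7-fold lower number from compound 2 to compound 3 (0.23 log units; within the scatter), and in place of diethylamino it gives a 1.1-fold higher number from compound 1 to compound 3 (0.05 log units; within the scatter). This place on a saturated chain carbon, two bonds along the chain from an amide-type nitrogen, has now carried three different groups, one of them a ring with a second nitrogen, with no step beyond the scatter. No measurement here gives a reason for these numbers. Still open, as far as these compounds go, is whether a morpholine ring, a carboxylic acid or a longer chain here would give a step beyond the scatter.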